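Moving Two Chlorines on a Benzyl Sulfide Series

The compounds below may be only part of what the source reports. "The series", "measured", "known", "first", "only" and "open" are said of these compounds alone.

The study compares four compounds that share a core and differ in two places. Compound 1 `Cc1ccsc1/C=C(/SCc1ccc(Cl)c(Cl)c1)C(=O)c1ccc(Cl)cc1` and compound 3 `CN(C)c1ccc(/C=C(/SCc2ccc(Cl)c(Cl)c2)C(=O)c2ccc(Cl)cc2)cc1` differ at the core: 4-(dimethylamino)phenyl in place of 3-methylthiophen-2-yl on a double-bonded chain carbon bound to a double-bonded chain carbon. In a functional assay on DU-145 cells (Homo sapiens) for inhibition, read by trypan blue exclusion, with a stated time of 96 h (on this read-out lower numbers stand for stronger inhibition of growth and higher numbers for weaker inhibition of growth), compound 1 gives 50000 nM, and compound 3 gives 50000 nM, so the cores sit level here: no change at the digits printed from compound 1 to compound 3 (within the scatter). Compound 2 `Cc1ccsc1/C=C(/SCc1ccc(Cl)cc1Cl)C(=O)c1ccc(Cl)cc1` carries the other change, relative to compound 1: 2,4-dichlorophenyl in place of 3,4-dichlorophenyl on a saturated chain carbon bound to a sulfur. In this assay compound 2 gives 10000 nM, a modest but real step: a 5.0-fold lower number from compound 1 to compound 2 (0.70 log units; beyond the scatter). Compound 4 `CN(C)c1ccc(/C=C(/SCc2ccc(Cl)cc2Cl)C(=O)c2ccc(Cl)cc2)cc1`, not yet measured, carries that same change made on the core of compound 3: 2,4-dichlorophenyl in place of 3,4-dichlorophenyl on a saturated chain carbon bound to a sulfur. The place is the same in both pairs, so the change is the same, and compound 3 starts level with compound 1. Among the compounds with values here, compound 4 is therefore expected to move by about a 4.2-fold lower number from compound 3 to compound 4 (0.62 log units; beyond the scatter), resting on the single step seen from compound 1 to compound 2, with wide uncertainty since it was seen only once. Compound 4 is estimated at 12000 nM, with a range from 4000 nM to 50000 nM.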

Compound 4, concentration for 50% growth inhibition: 50000 nM
Compound 4: the middle estimate sits 4.2-fold (0.62 log units) below what was measured; low and high end bracket the measured number.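

In this assay, 2,4-dichlorophenyl in place of 3,4-dichlorophenyl gives no change at the digits printed from compound 3 to compound 4 (within the scatter), so this change does not act alike on the two cores: the same change on two cores in this assay, a 5.0-fold lower number (0.70 log units; beyond the scatter) from compound 1 to compound 2 and no change at the digits printed (within the scatter) from compound 3 to compound 4, 5.0-fold (0.70 log units) apart, beyond the scatter of two such steps. Read the other way, 4-(dimethylamino)phenyl in place of 3-methylthiophen-2-yl gives a 5.0-fold higher number from compound 2 to compound 4 (0.70 log units; beyond the scatter), although the same swap made no difference with the 3,4-dichlorophenyl group in place: the same change on two cores in this assay, no change at the digits printed (within the scatter) from compound 1 to compound 3 and a 5.0-fold higher number (0.70 log units; beyond the scatter) from compound 2 to compound 4, 5.0-fold (0.70 log units) apart, beyond the scatter of two such steps. Together these comparisons show that the step on one core did not predict the step on the other in this series, but they rest on a single set of four compounds and do not show why the two cores part, or how the change would behave on any further core.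

On these data alone, it remains open whether the step seen from the 3-methylthiophen-2-yl core is particular to that group or extends to other cores. Also open, as far as these compounds go, is what a plain phenyl in place of the dichlorophenyl groups, or a carboxylic acid in place of the 4-(dimethylamino)phenyl group, would do in this assay.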